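Two Aryl Groups on a Shared Core

A few compounds are considered here, and "the series" means these few. Any claim that something is new, unique, unknown or untested is made for them only; others in the source may bear on it.

Measured so far:
compound 1, `N#CC1=C(N)Oc2c(c3nc4ccccc4nc3c3ccccc23)C12C(=O)N(Cc1cnnn1-c1ccc(Br)cc1)c1ccccc12`, gives > 50000 nM in an ADME assay on HUVEC cells (Homo sapiens) for antiproliferative activity, read by MTT assay, with a stated time of 48 h; a higher number here means a weaker inhibitor, a lower number a stronger inhibitor
compound 2, `CC(=O)Nc1ccc(-n2nncc2CN2C(=O)C3(C(C#N)=C(N)Oc4c3c3nc5ccccc5nc3c3ccccc43)c3ccccc32)cc1`, gives > 50000 nM in this assay

The value recorded for compound 1 in this assay is a limit of the assay, not a number. The value for compound 2 is likewise a limit. Compound 1 and compound 2 differ only by acetamido in place of bromo on an aromatic carbon, and the step that the two limits leave unreadable from compound 1 to compound 2 cannot be read, since (the limit of > 50000 nM in this assay, at which 2 of the 2 values shown sit).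

Compound 3, `Cc1cc(C)cc(-n2nncc2CN2C(=O)C3(C(C#N)=C(N)Oc4c3c3nc5ccccc5nc3c3ccccc43)c3ccccc32)c1`, is the next compound in line. It differs from compound 1 as follows: 3,5-dimethylphenyl in place of 4-bromophenyl on an aromatic nitrogen. Among the measured compounds shown here, the only measured step that touches the same part of the molecule is the one from compound 1 to compound 2, and that step has no readable size. For the measured compounds named here, no measured step therefore shows any change at this position to move the read-out away from the limit, and compound 3 is expected to sit where compound 1 sits, a step of a number no higher from compound 1 to compound 3 (the limit leaves the size open) of no readable size. On that basis compound 3 is estimated at 50000 nM in this assay, within a range from 20000 nM to 150000 nM, most likely again reported only as a limit.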

Compound 3, half-maximal inhibitory concentration: > 50000 nM
Compound 3: no number, only a limit; the forecaster's own chance of this, stated with the estimate: 80%; the middle value sits exactly at the limit.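

The value for compound 3, > 50000 nM, is again a limit of the assay and not a number. The steps from compound 1 and from compound 2 to compound 3 therefore cannot be read: the limit of > 50000 nM in this assay, at which 3 of the 3 values shown sit.

The compounds shown leave open whether any group on that aromatic nitrogen would give a measurable value in this assay.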